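Pyridin-4-yl in place of pyridin-3-yl on the shared core

The source may hold more compounds than are shown below. What is called first, only, known or untested is meant among the compounds shown, and "the series" means these compounds.

Measured in a functional assay on ileum (Cavia porcellus) for inhibition; on this read-out higher numbers stand for weaker inhibition and lower numbers for stronger inhibition:
- compound 1 `COC(=O)C1=C(C)NC(C)=C(C(=O)OC)C1c1c(-c2ccncc2)nc2sc(C)cn12`: 9690 nM
- compound 2 `COC(=O)C1=C(C)NC(C)=C(C(=O)OC)C1c1c(-c2cccnc2)nc2sccn12`: 3550 nM

Compound 2, at 3550 nM, stands lowest of the two numbers, and compound 1 lies above it by more than the scatter. Compound 3 `COC(=O)C1=C(C)NC(C)=C(C(=O)OC)C1c1c(-c2ccncc2)nc2sccn12` has not yet been measured. It differs from compound 2 in one place, with pyridin-4-yl in place of pyridin-3-yl on an aromatic carbon. Among the measured compounds shown here, no measured pair shows this change alone, so any expectation rests on thin evidence. Compound 1 also carries pyridin-4-yl and gives 9690 nM, which points to a small move towards weaker inhibition in this assay. The expected step is a 1.5-fold higher number from compound 2 to compound 3 (0.19 log units; within the scatter). For compound 3 the estimated value is 5500 nM, with an expected range from 1800 nM to 16000 nM.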

Compound 3, half-maximal inhibitory concentration: 960 nM
Beside the measured number, compound 3's estimate is 5.7-fold (0.76 log units) above it; measured number outside the range, below it.
By their numbers in this assay, from the lowest: compound 3; then compound 2; then compound 1.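

In this assay, the position on the aromatic carbon carrying the pyridine ring responds to where the ring nitrogen lies: pyridin-4-yl in place of pyridin-3-yl gives a 3.7-fold lower number from compound 2 to compound 3 (0.57 log units; beyond the scatter), although the two groups share the same atoms and the same counts. The methyl group also matters, as hydrogen in place of methyl on an aromatic carbon gives a 10-fold lower number from compound 1 to compound 3 (1.00 log units; beyond the scatter), so the high number of compound 1 says little about pyridin-4-yl alone. Nothing available accounts for either step.

From the compounds shown here alone, each change rests on a single pair, so whether pyridin-4-yl keeps its lower number when the methyl group is present remains open. Also open, going by these compounds, is how pyridin-2-yl or a plain phenyl ring would read at the same carbon, and whether an ethyl group would track methyl.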